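Thiazolyl Amide Variant in a Cinnamate Ester Series

The source may hold more compounds than are shown below. What is called first, only, known or untested is meant among the compounds shown, and "the series" means these compounds.

Compound 1, `COCOc1cc(/C=C/C(=O)OCC(=O)Nc2ccc(Cl)cc2)ccc1OCc1ccccc1`, in a functional assay on CNE cells (Homo sapiens) for cytotoxicity, read by MTT assay, with a stated time of 72 h (a lower number here means a stronger inhibitor, a higher number a weaker inhibitor), gives > 200000 nM, which is a limit of the assay and not a number.
Compound 2, `COCOc1cc(/C=C/C(=O)OCC(=O)NN2CCOCC2)ccc1OCc1ccccc1`, in this assay gives > 200000 nM, again a limit rather than a number.

For the measured compounds named here, the one step between measured compounds, a step that the two limits leave unreadable from compound 1 to compound 2, cannot be read in either direction, since both values sit at the limit of > 200000 nM in this assay, at which 2 of the 2 values shown sit. Compound 2 therefore stands only at that limit; no number places it anywhere on the scale.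

Compound 3, `COCOc1cc(/C=C/C(=O)OCC(=O)Nc2nccs2)ccc1OCc1ccccc1`, differs from compound 2 by 1,3-thiazol-2-yl in place of morpholin-4-yl on an amide-type nitrogen. Going by the values given here, no measured step bears on this exchange, as the single recorded step is unreadable. The step to compound 3 is expected to show no readable change beyond the scatter, a number no higher from compound 2 to compound 3 (the limit leaves the size open). Compound 3 is accordingly estimated at 200000 nM in this assay, within a range from 60000 nM to 400000 nM, most likely reported as a limit again.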

Compound 3, half-maximal inhibitory concentration: > 200000 nM
Compound 3: a limit, no number; the forecaster's own chance of this, stated with the estimate: 75%; the middle value lies on the limit itself.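

Compound 3 also gives only a limit of the assay and not a number, so the steps to compound 3 from compound 1 and from compound 2 cannot be read: the limit of > 200000 nM in this assay, at which 3 of the 3 values shown sit.

The compounds shown leave open how strongly any of the three inhibits these cells, and whether the group on the amide-type nitrogen changes that strength at all.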